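Swapping one amine on a shared core of four compounds

A few compounds are considered here, and "the series" means these few. Any claim that something is new, unique, unknown or untested is made for them only; others in the source may bear on it.

Compound 1 `CCC(CC)Nc1nc(C)nc2c(-c3cc(F)c(OC)cc3Cl)c(C)nn12`, compound 2 `CCN(CC)c1nc(C)nc2c(-c3cc(OC)c(OC)cc3Br)c(C)nn12` and compound 3 `CCN(CC)c1nc(C)nc2c(-c3cc(F)c(OC)cc3Cl)c(C)nn12` have been measured, while compound 4 `CCC(CC)Nc1nc(C)nc2c(-c3cc(OC)c(OC)cc3Br)c(C)nn12` has not. In an assay on cell membranes for displacement of a labelled ligand from corticotropin-releasing factor receptor 1 (Rattus norvegicus) (a lower number here means a stronger inhibitor, a higher number a weaker inhibitor), compound 1 gives 1 nM, compound 3 gives 1.64 nM, and compound 2 gives 4.06 nM, the highest of the three. Compound 3 and compound 1 differ in one place ((pentan-3-yl)amino in place of diethylamino on an aromatic carbon), and that step is a 1.6-fold lower number from compound 3 to compound 1 (0.21 log units; within the scatter). How the core of compound 2 differs from that of compound 3 is not broken down here. The same change separates compound 2 from compound 4 ((pentan-3-yl)amino in place of diethylamino on an aromatic carbon), at a place described in the same words. Compound 4 is expected to move by a 1.6-fold lower number from compound 2 to compound 4 (0.21 log units; within the scatter) in this assay because the earlier step was a 1.6-fold lower number from compound 3 to compound 1 (0.21 log units; within the scatter). Compound 4 is therefore estimated at 2.5 nM in this assay, likely between 1.2 nM and 5.5 nM.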

Compound 4, half-maximal inhibitory concentration: 6.08 nM
Compound 4: middle estimate off by 2.4-fold (0.39 log units), on the low side, and the stated range ends below it.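

In this assay, putting (pentan-3-yl)amino in place of diethylamino on the core of compound 2 gives a 1.5-fold higher number from compound 2 to compound 4 (0.18 log units; within the scatter). Set beside the earlier step, the two results do not differ by more than repeated measurements can account for: the same change on two cores in this assay, a 1.6-fold lower number (0.21 log units; within the scatter) from compound 3 to compound 1 and a 1.5-fold higher number (0.18 log units; within the scatter) from compound 2 to compound 4, 2.5-fold (0.39 log units) apart, within the scatter of two such steps. On these two cores, then, the swap has no effect that can be told apart from scatter, and the opposite directions of the two steps carry no weight, but two cores cannot show that the two amines are interchangeable across the series, and a small real effect could be hidden in the scatter.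

The compounds shown leave open how other amines in this place, such as morpholine or dipropylamino, would compare. They also leave open whether the swap would stay this small on a core carrying different groups.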